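A few compounds are considered here, and "the series" means these few. Any claim that something is new, unique, unknown or untested is made for them only; others in the source may bear on it.

Series values in a functional assay on HepG2 cells (Homo sapiens) for inhibition, read by MTT assay, with a stated time of 72 h; a higher number here means a weaker inhibitor, a lower number a stronger inhibitor:
- Compound 1 `CNC(=O)CCCCCCCn1nc(-c2cnc3[nH]ccc3c2)c2c(N)ncnc21`: 5630 nM
- Compound 2 `Nc1ncnc2c1c(-c1cnc3[nH]ccc3c1)nn2CC(=O)NO`: > 150000 nM, which is a limit of the assay and not a number.
- Compound 3 `Nc1ncnc2c1c(-c1cnc3[nH]ccc3c1)nn2CCCCCC(=O)NO`: 12900 nM

Of the two true numbers, compound 3 has the higher, with a 2.3-fold higher number from compound 1 to compound 3 (0.36 log units; beyond the scatter).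

The next analogue is compound 4 `Nc1ncnc2c1c(-c1cnc3[nH]ccc3c1)nn2CCCC(=O)NO`, and the change is hydroxycarbamoyl in place of 2-(hydroxycarbamoyl)ethyl on a saturated chain carbon, three bonds along the chain from an aromatic nitrogen. The same difference, cut further out, reads 5-(hydroxycarbamoyl)pentyl to 3-(hydroxycarbamoyl)propyl.

The most relevant measured step is an at least 11-fold lower number from compound 2 to compound 3 (1.06 log units; beyond the scatter). It is large, keeps the hydroxycarbamoyl end and changes only the chain, but it rests on a limit: the limit of > 150000 nM in this assay, at which 1 of the 3 values shown sits. Compound 4 carries a chain length that falls between those of compound 2 and compound 3, so it should land between these two compounds. The steps of an at least 26-fold higher number from compound 1 to compound 2 (1.42 log units; beyond the scatter) and a 2.3-fold higher number from compound 1 to compound 3 (0.36 log units; beyond the scatter) also change the end group, so they bear less directly.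

A higher number than that of compound 3 is expected, with a step beyond the scatter but smaller than the full step separating compound 2 and compound 3. The expected change is a 3.1-fold higher number from compound 3 to compound 4 (0.49 log units; beyond the scatter). For compound 4 the estimated value is 40000 nM, with an expected range from 16000 nM to 120000 nM.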

Compound 4, half-maximal inhibitory concentration: > 50000 nM
Compound 4: a limit, no number; the forecaster's own chance of this, stated with the estimate: 20%; middle value at least 1.2-fold (0.09 log units) away from the limit.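

Compound 4 reads as a limit and not a number in this assay: the limit of > 50000 nM in this assay, at which 1 of the 4 values shown sits.

Cutting 5-(hydroxycarbamoyl)pentyl back to 3-(hydroxycarbamoyl)propyl with the hydroxycarbamoyl end kept gives an at least 3.8-fold higher number from compound 3 to compound 4 (0.58 log units; beyond the scatter), so the loss is already visible at this shorter chain and not only at the (hydroxycarbamoyl)methyl of compound 2, and the change from the 4-(methylcarbamoyl)butyl level of the chain gives an at least 8.8-fold higher number from compound 1 to compound 4 (0.94 log units; beyond the scatter). Compound 2 and compound 4 both stand as limits, the step between them cannot be read, and the series gives no order between these two chains, only that both lie on the weaker side of compound 3.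

Open, going by these compounds, is how a chain longer than 5-(hydroxycarbamoyl)pentyl, such as 7-(hydroxycarbamoyl)heptyl, would read with the hydroxycarbamoyl end kept. Equally open, on these data alone, is what the end group alone contributes at one fixed chain length, which a carboxylic acid or a methylcarbamoyl group on the pentyl chain of compound 3 would separate from the effect of chain length.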